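Methoxy to Trifluoromethyl at a Limit of Detection

This account rests on a few compounds, and the source may have more. Where it says the series, first, only, none or still open, it means among the compounds named here.

Compound 1 `O=S(=O)(Nc1ccc(-c2nc3ccccc3o2)cc1)c1ccccc1F` and compound 2 `COc1ccccc1S(=O)(=O)Nc1ccc(-c2nc3ccccc3o2)cc1` share the same core and differ in a single group on an aromatic carbon, the step being methoxy in place of fluoro. In an assay on isolated protein for inhibition of malate dehydrogenase, mitochondrial (Sus scrofa), with stated times of 45 min and 30 min (a lower number here means a stronger inhibitor, a higher number a weaker inhibitor), compound 1 gives only a limit of the assay, > 63000 nM. In this assay compound 2 likewise gives only a limit, > 63000 nM. The step from compound 1 to compound 2, a step that the two limits leave unreadable from compound 1 to compound 2, therefore has no readable size, because both values sit at the limit of > 63000 nM in this assay, at which 2 of the 2 values shown sit. So far, then, compound 2 stands at the weak end of what this assay can report, with no number attached to it.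

Compound 3 `O=S(=O)(Nc1ccc(-c2nc3ccccc3o2)cc1)c1ccccc1C(F)(F)F` carries the next change: trifluoromethyl in place of methoxy on an aromatic carbon. Among the compounds with values here, the only measured step that bears on this position is the unreadable one from compound 1 to compound 2, so no direction or size can be drawn from it. The expectation for compound 3 in this assay is accordingly an estimated step that the limit leaves unreadable from compound 2 to compound 3, that is, nothing beyond the scatter. Compound 3 is therefore estimated at 80000 nM, in a range from 20000 nM to 300000 nM, most likely again a limit rather than a number.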

Compound 3, half-maximal inhibitory concentration: > 63000 nM
Compound 3 gave a limit, no number (the forecaster's own chance of this, stated with the estimate: 75%); the middle value does not contradict the limit.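

Within the data shown here, no step between compound 1, compound 2 and compound 3 can be read in this assay, because each of the three gives only a limit and not a number: (the limit of > 63000 nM in this assay, at which 3 of the 3 values shown sit). The compounds shown leave open whether any group at this place on the shared core gives a readable value, and how fluoro, methoxy and trifluoromethyl compare.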